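A Hydroxyethyl Amide Variant of Compound 1

This account rests on a few compounds, and the source may have more. Where it says the series, first, only, none or still open, it means among the compounds named here.

Compound 1 `COc1cc2c(cc1OC)C(CC(=O)NC(C)C)CC2` gives 37% in a functional assay on the whole organism (strain Wistar) for inhibition, with Rattus norvegicus as the target, read by paw edema, with stated times of 60 min and 6 h, at a dose of 100 mg/kg by the oral route (on this read-out lower numbers stand for less inhibition and higher numbers for more inhibition at the one dose given (going by the name of the read-out)), and compound 2 `COc1cc2c(cc1OC)C(CC(=O)NCc1ccccc1)CC2` gives 30.6%; the two lie within the scatter of each other, as the step of a number 6.4 percentage points lower from compound 1 to compound 2 (within the scatter) shows. Compound 3 `COc1cc2c(cc1OC)C(CC(=O)NCCO)CC2` differs from compound 1 by 2-hydroxyethyl in place of isopropyl on an amide-type nitrogen. For the measured compounds named here, the only measured step, at the same amide-type nitrogen, exchanged isopropyl for benzyl and stayed within the scatter; no measured step involves 2-hydroxyethyl. Compound 3 is therefore expected to show a step of a number 4 percentage points lower from compound 1 to compound 3 (within the scatter), nothing beyond the scatter. The estimate for compound 3 is 33%, with a range from 20% to 46%.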

Compound 3, a percentage reported as inhibition, in the whole organism at one dose (the size of the read-out at that dose, not a potency): 13%
Estimate against measurement, compound 3: 20 percentage points above; the measured number lies below the stated range.
By their numbers in this assay, from the lowest: compound 3; then compounds 2 and 1 (each within the scatter of the next).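

In this assay the group on the amide-type nitrogen proves to matter: 2-hydroxyethyl in place of isopropyl gives a number 24 percentage points lower from compound 1 to compound 3 (beyond the scatter) and hydroxymethyl in place of phenyl gives a number 17.6 percentage points lower from compound 2 to compound 3 (beyond the scatter) on the same chain. The isopropyl-to-benzyl exchange had suggested little sensitivity here, yet this change, with an equal heavy-atom count on both sides, makes a clear difference. Nothing given here accounts for the loss.

Still open, going by these compounds, is whether the hydroxyl itself or the chain carrying it sets the result. A 2-methoxyethyl group, a 3-hydroxypropyl chain or a 2-aminoethyl group at this nitrogen would separate these.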